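Amide to sulfonamide on a shared chalcone-like core

The compounds below may be only part of what the source reports. "The series", "measured", "known", "first", "only" and "open" are said of these compounds alone.

Compound 1 `Cc1ccc(C(=O)Nc2cccc(/C=C/C(=O)c3nc4ccccc4[nH]3)c2)cc1` and compound 2 `O=C(Nc1cccc(/C=C/C(=O)c2nc3ccccc3[nH]2)c1)c1cc(Cl)cc(Cl)c1` share one core and differ only in the aryl group on the carbonyl carbon. In a functional assay on 143B cells (Homo sapiens) for antiproliferative activity, read by MTT assay, with a stated time of 48 h (a lower number here means a stronger inhibitor, a higher number a weaker inhibitor), compound 1 gives 6560 nM, and compound 2 gives 3660 nM; the step of a 1.8-fold lower number from compound 1 to compound 2 (0.25 log units; within the scatter) lies within the scatter, so the two sit together. Compound 3 `Cc1cccc(S(=O)(=O)Nc2cccc(/C=C/C(=O)c3nc4ccccc4[nH]3)c2)c1` differs from compound 2 by (3-methylphenyl)sulfonyl in place of (3,5-dichlorophenyl)carbonyl on a nitrogen on an aromatic ring. For the measured compounds named here, no measured step touches this change; the one measured step was small. Compound 3 is therefore expected near compound 2, with a 1.2-fold higher number from compound 2 to compound 3 (0.09 log units; within the scatter), and an estimate of 4500 nM in this assay, between 1500 nM and 14000 nM.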

Compound 3, half-maximal inhibitory concentration: 791 nM
Compound 3: middle estimate off by 5.7-fold (0.76 log units), on the high side, outside the stated range (below it).
By their numbers in this assay, from the lowest: compound 3; then compounds 2 and 1 (each within the scatter of the next).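

Changing the aryl group on the carbonyl carbon had stayed within the scatter, but replacing the carbonyl-linked group on the nitrogen with a sulfonyl-linked one goes beyond it in this assay: a 4.6-fold lower number from compound 2 to compound 3 (0.67 log units; beyond the scatter) and an 8.3-fold lower number from compound 1 to compound 3 (0.92 log units; beyond the scatter). Both steps change the aryl group as well as the link, so the two changes cannot be told apart. Nothing available explains the lower number.

The compounds shown leave open how a (3,5-dichlorophenyl)sulfonyl or (4-methylphenyl)sulfonyl group would compare with compound 3. Also open, going by these compounds, is what a methylsulfonyl group, with no aryl ring, would give.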